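The compounds below may be only part of what the source reports. "The series", "measured", "known", "first", "only" and "open" are said of these compounds alone.

Measured compounds in a toxicity assay on cells (Macrophage, Mus musculus, strain BALB/c) for cytotoxicity, read by MTT assay; a higher number here means a weaker inhibitor, a lower number a stronger inhibitor:

Compound 1, `COc1cc(O)cc(O)c1C(=O)/C=C/c1ccc(C(F)(F)F)cc1`, gives 17100 nM.
Compound 2, `C=CCOc1cc(OC)c(C(=O)/C=C/Cc2ccccc2)c(OCC=C)c1`, gives 14800 nM.
Compound 3, `C=CCOc1cc(OC)c(C(=O)/C=C/c2cc(OC)c(OC)c(OC)c2)c(OCC=C)c1`, gives 12000 nM.

These three numbers lie within the usual scatter of one another, so compound 2 stands level with compound 1 and with compound 3; none of the three can be called more or less damaging to the cells than the others on this evidence. Compound 4, `C=CCOc1cc(OC)c(C(=O)/C=C/c2ccccc2F)c(OCC=C)c1`, has not yet been measured. It differs from compound 2 in a single place: 2-fluorophenyl in place of benzyl on a double-bonded chain carbon bound to a double-bonded chain carbon. Among the compounds with values here, no pair of measured compounds differs in just one place, so there is no measured step from which to read off the effect of such an exchange. What is known is that three rather different structures all land at about the same number in this assay, which gives no reason to expect compound 4 to move far from compound 2. The step from compound 2 to compound 4, estimated as a 1.0-fold lower number from compound 2 to compound 4 (0.01 log units; within the scatter), is expected to stay within the scatter. For compound 4 the expected value is 14500 nM, with a range from 7000 nM to 30000 nM.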

Compound 4, half-maximal inhibitory concentration: 13300 nM
Estimate against measurement, compound 4: 1.1-fold (0.04 log units) above, within the range that was stated.
By their numbers in this assay, from the lowest: compounds 3, 4, 2 and 1 (each within the scatter of the next).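

Within the data shown here, this is the first exchange that can be read at a single place. In this assay, 2-fluorophenyl in place of benzyl on a double-bonded chain carbon bound to a double-bonded chain carbon gives a 1.1-fold lower number from compound 2 to compound 4 (0.05 log units; within the scatter), so compound 2 and compound 4 stand level, and this read-out does not tell the two groups apart at this place. Nothing measured here bears on why they stand level.

This one exchange says nothing about whether a group of another kind at the same place, such as an amine, a carboxylic acid or a longer chain, would also stay level with compound 2. It also leaves open whether the same exchange would read the same way on another core, such as that of compound 1.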